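Fluoro to bromo on the aryl group

A few compounds are considered here, and "the series" means these few. Any claim that something is new, unique, unknown or untested is made for them only; others in the source may bear on it.

Measured in a functional assay on PC-3 cells (Homo sapiens) for cytotoxicity, read by MTT assay, with a stated time of 72 h; on this read-out higher numbers stand for weaker inhibition and lower numbers for stronger inhibition:
Compound 1 `CNC(=O)c1cc(Oc2ccc(C3=NNC(c4ccc(Cl)cc4Cl)C3)cc2)ccn1`: 7300 nM
Compound 2 `CNC(=O)c1cc(Oc2ccc(C3=NNC(c4ccc(F)cc4)C3)cc2)ccn1`: 6770 nM

Among the measured compounds shown here, compound 2 stands level with compound 1, the only other compound measured. Compound 3 `CNC(=O)c1cc(Oc2ccc(C3=NNC(c4ccc(Br)cc4)C3)cc2)ccn1` follows from compound 2 by one exchange, (bromo in place of fluoro on an aromatic carbon), bromo in place of fluoro on an aromatic carbon. For the measured compounds named here, one measured step bears on this, a change on the same aryl group: a 1.1-fold lower number from compound 1 to compound 2 (0.03 log units; within the scatter). As that step stayed within the scatter, no step beyond the scatter is expected in this assay. The estimated change is a 1.1-fold lower number from compound 2 to compound 3 (0.03 log units; within the scatter). Compound 3 is expected at 6300 nM, with an estimated range from 2900 nM to 13500 nM.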

Compound 3, half-maximal inhibitory concentration: > 50000 nM
Compound 3: only a limit was reported (the forecaster's own chance of this, stated with the estimate: 5%); middle value at least 7.9-fold (0.89 log units) away from the limit.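

In this assay, the para position of this aryl group proves sensitive to the halogen: the exchange of fluoro for bromo gives an at least 7.3-fold higher number from compound 2 to compound 3 (0.86 log units; beyond the scatter), whereas the earlier change on the same aryl group, a 1.1-fold lower number from compound 1 to compound 2 (0.03 log units; within the scatter), showed no such separation. The 4-bromophenyl group also stands apart from the 2,4-dichlorophenyl group, with an at least 6.8-fold higher number from compound 1 to compound 3 (0.83 log units; beyond the scatter). Compound 3 is recorded only as a limit, not as a number: the limit of > 50000 nM in this assay, at which 1 of the 3 values shown sits.

As far as these compounds go, the full size of both new steps therefore stays open. So does whether a chloro, methyl or methoxy group at this para position would read like fluoro or like bromo.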